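A few compounds are considered here, and "the series" means these few. Any claim that something is new, unique, unknown or untested is made for them only; others in the source may bear on it.

Measured so far:
Compound 1 `C[C@H](c1ccc(F)cc1)N(Cc1cccc(C(=O)O)c1)C(=O)c1ccc(Oc2ccccc2)cc1` — in an assay on CHO T-rex cells for antagonist activity at transient receptor potential cation channel subfamily M member 8 (Homo sapiens), read by calcium flux, with a stated time of 20 min (on this read-out higher numbers stand for weaker inhibition and lower numbers for stronger inhibition), compound 1 gives only a limit, > 6160 nM.
Compound 2 `C[C@H](c1ccc(F)cc1)N(Cc1cccc(C(=O)O)n1)C(=O)c1cnc2ccccc2c1` — in this assay compound 2 gives 1160 nM.

Compound 2 holds the only real number shown. The value of compound 1 is the limit of > 6160 nM in this assay, at which 1 of the 2 values shown sits. Compound 3 `C[C@H](c1ccc(F)cc1)N(Cc1cc(C(=O)O)ccc1F)C(=O)c1cnc2ccccc2c1` has not been measured. It differs from compound 2 in one place: 5-carboxy-2-fluorophenyl in place of 6-carboxypyridin-2-yl on a saturated chain carbon bound to an amide-type nitrogen. Going by the values given here, no measured pair shows this exchange. In this assay the change is expected to move the result little, if at all, beyond the usual scatter, perhaps slightly toward weaker inhibition. Compound 3 is estimated at 1600 nM, with a range from 500 nM to 5000 nM. The expected step is a 1.4-fold higher number from compound 2 to compound 3 (0.14 log units; within the scatter).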

Compound 3, half-maximal inhibitory concentration: 446 nM
The estimate for compound 3 lay 3.6-fold (0.55 log units) above the measured number, outside the stated range (below it).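

In this assay, 5-carboxy-2-fluorophenyl in place of 6-carboxypyridin-2-yl on a saturated chain carbon bound to an amide-type nitrogen gives a 2.6-fold lower number from compound 2 to compound 3 (0.42 log units; beyond the scatter), so the result at this position depends on the ring that carries the carboxy group. A ring of carbon only with fluorine is tolerated here. Nothing measured among these compounds accounts for the step.

As far as these compounds go, the ring nitrogen leaves and the fluorine enters together, so their separate shares remain open. So does whether a nitrile or an amine could replace the carboxylic acid.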